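Oral exposure after replacing oxetan-3-yl with (hydroxymethyl)carbonyl

This account rests on a few compounds, and the source may have more. Where it says the series, first, only, none or still open, it means among the compounds named here.

In an ADME assay on the whole organism (Mus musculus, strain CB17) for pharmacokinetics, at a dose of 30 mg/kg by the oral route (on this read-out lower numbers stand for lower exposure and higher numbers for higher exposure at the dose given), compound 1 (`C[C@@H](Oc1cc(C(=O)N(C)C)ccc1Nc1nc(O[C@H]2CC[C@@](C)(O)CC2)c2c(Cl)c[nH]c2n1)C(F)(F)F`) gives 5200 nM and compound 2 (`COc1cc(N2CCN(C3COC3)CC2)ccc1Nc1nc(O[C@H]2CCOC(C)(C)C2)c2cc[nH]c2n1`) gives 11800 nM as the higher of the two numbers, with a gap beyond the scatter. These two compounds differ in more than one place, so their gap cannot be tied to any single group.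

Compound 3 (`COc1cc(N2CCN(C(=O)CO)CC2)ccc1Nc1nc(O[C@H]2CCOC(C)(C)C2)c2cc[nH]c2n1`) departs from compound 2 at one point, an amine nitrogen in a ring: (hydroxymethyl)carbonyl in place of oxetan-3-yl ((hydroxymethyl)carbonyl in place of oxetan-3-yl on an amine nitrogen in a ring). In the same words, 4-(oxetan-3-yl)piperazin-1-yl becomes 4-((hydroxymethyl)carbonyl)piperazin-1-yl.

Going by the values given here, no measured pair shows this change, so the expectation has little support and the range is kept wide. Because compound 2 at 11800 nM holds the higher of the two numbers, a fall looks likelier than a rise. The estimated step (a 2.4-fold lower number from compound 2 to compound 3 (0.37 log units; beyond the scatter)) is downward and is expected to lie modestly beyond the scatter. For compound 3 the expected value in this assay is 5000 nM with 1500 nM and 13000 nM as the estimated lower and upper ends.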

Compound 3, maximal plasma concentration: 9860 nM
For compound 3 the middle estimate is 2.0-fold (0.29 log units) below the measured one; the range from low to high includes it.
By their numbers in this assay, from the lowest: compounds 1, 3 and 2 (each within the scatter of the next, the first and the last beyond it).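

In this assay, replacing oxetan-3-yl with (hydroxymethyl)carbonyl on the amine nitrogen in a ring gives a 1.2-fold lower number from compound 2 to compound 3 (0.08 log units; within the scatter); this is the only comparison shown that isolates a single place, and on this read-out it does not separate the two groups at this position. The entering group carries a hydrogen-bond donor and no ring, whereas oxetan-3-yl carries a four-membered non-aromatic ring and no donor, yet compound 2 and compound 3 remain within the scatter of each other. Nothing available explains this outcome.

Still open, on these data alone, is whether an acetyl group, a 2-aminoacetyl group or a carboxymethyl group on the same amine nitrogen would also remain within the scatter of compound 2 in this assay. One pair also leaves open whether this result extends beyond the 4-substituted piperazin-1-yl compounds that share the rest of compound 2, and compound 1, which has no piperazine, offers no test of it.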